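This account rests on a few compounds, and the source may have more. Where it says the series, first, only, none or still open, it means among the compounds named here.

Measured compounds:
- Compound 1, `CC(C)[C@H](NC(=O)c1ccc(C(=O)Nc2ccc3c(c2)C(C)(C)CCC3(C)C)cc1)C(=O)OCc1c(-c2ccccc2)no[n+]1[O-]`: 5850 nM
- Compound 2, `CC1(C)CCC(C)(C)c2cc(NC(=O)c3ccc(C(=O)OCCCOC(=O)c4ccc(OCc5c(-c6ccccc6)no[n+]5[O-])cc4)cc3)ccc21`: 185000 nM

Of the compounds shown here, two from this series have been tested in a functional assay on HL-60 cells (Homo sapiens) for antiproliferative activity, read by MTT assay, with a stated time of 48 h; on this read-out lower numbers stand for stronger inhibition and higher numbers for weaker inhibition. Compound 1 `CC(C)[C@H](NC(=O)c1ccc(C(=O)Nc2ccc3c(c2)C(C)(C)CCC3(C)C)cc1)C(=O)OCc1c(-c2ccccc2)no[n+]1[O-]` gives 5850 nM, which is the lower of the two numbers available. Compound 2 `CC1(C)CCC(C)(C)c2cc(NC(=O)c3ccc(C(=O)OCCCOC(=O)c4ccc(OCc5c(-c6ccccc6)no[n+]5[O-])cc4)cc3)ccc21` gives 185000 nM. Among the compounds with values here, the two values lie far apart, beyond the scatter of this assay, but the two structures differ in more than one place, so no single-change step connects them and nothing can be said about which part of the difference matters.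

Compound 3 `CC(C)C[C@H](NC(=O)c1ccc(C(=O)Nc2ccc3c(c2)C(C)(C)CCC3(C)C)cc1)C(=O)OCc1c(-c2ccccc2)no[n+]1[O-]` has not yet been measured. It differs from compound 1 in one place only: isobutyl in place of isopropyl on a saturated chain carbon bound to an amide-type nitrogen and a carbonyl carbon. Within the data shown here, no pair of measured compounds shows what such a change does here, so the expectation rests on the size of the change alone, which is small and leaves every other part of compound 1 in place. The step of a 1.1-fold lower number from compound 1 to compound 3 (0.03 log units; within the scatter) is expected to stay within the scatter, with no clear direction. Compound 3 is therefore estimated at 5500 nM, in a range from 2000 nM to 15000 nM.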

Compound 3, half-maximal inhibitory concentration: 740 nM
Estimate against measurement, compound 3: 7.4-fold (0.87 log units) above, outside the stated range (below it).
By their numbers in this assay, from the lowest: compound 3; then compound 1; then compound 2.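

In this assay, isobutyl in place of isopropyl on the saturated chain carbon bound to an amide-type nitrogen and a carbonyl carbon gives a 7.9-fold lower number from compound 1 to compound 3 (0.90 log units; beyond the scatter), a step beyond the usual scatter. Within the data shown here, this is the first single-change step, and it shows that this position is not indifferent to its side chain: going from the 3 carbon atoms of isopropyl to the 4 of isobutyl, with no ring, hydrogen-bond donor, hydrogen-bond acceptor or net charge entering or leaving, is enough to shift the number while the rest of compound 1 stays in place. No measurement at hand accounts for the shift.

As far as these compounds go, a single step gives a direction for this one pair of groups only, so it remains open whether a longer chain such as n-hexyl or a ring-bearing group such as benzyl on the same carbon would lower the number further, keep it level or raise it. From the compounds shown here alone, it is equally open how a carboxylic acid or an amine at the end of that side chain would read in this assay.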